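The source may report more compounds than this note shows. Statements on the series, on what has been measured and on what is new or still open speak of the compounds shown alone.

Of the compounds shown here, three have so far been measured in a physicochemical assay for solubility, read by HPLC, in phosphate buffer, measured as kinetic solubility, at pH 7.4; a higher number here means a more soluble compound, a lower number a less soluble compound. Compound 1, `CCOC(=O)c1cc(-c2ccc(Cl)cc2)n(-c2ccc3cc[nH]c3c2)c1C`, gives 5100 nM. Compound 2, `CCC(=O)c1cc(-c2ccc(F)cc2)n(-c2ccc(S(N)(=O)=O)cc2)c1C`, gives 29300 nM in this assay. Compound 3, `CC(C)(C)C(=O)c1cc(-c2ccc(S(N)(=O)=O)cc2)n(-c2ccc(Cl)cc2)n1`, gives 6600 nM in this assay. Among these three numbers compound 3 holds the second highest. Its nearest neighbour is compound 1, and the two values lie within the scatter of each other, so no order can be read from them. Compound 2 stands furthest from compound 3, with a number higher by a margin that goes beyond the scatter.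

The next compound, compound 4, `NS(=O)(=O)c1ccc(-c2cc(C(=O)NN3CCCCC3)nn2-c2ccc(Cl)cc2)cc1`, has not yet been measured in this assay. It differs from compound 3 in one place: (piperidin-1-yl)amino in place of tert-butyl on a carbonyl carbon. The group that leaves is a tert-butyl, with no ring and no hydrogen-bond donor or acceptor; the group that enters is a (piperidin-1-yl)amino, which brings one six-membered non-aromatic ring with one hetero atom along with one hydrogen-bond donor and one hydrogen-bond acceptor. For the measured compounds named here, no pair of measured compounds shows this exact change, so there is no measured step to lean on. The expectation for compound 4 is a modest rise, a step of a 1.8-fold higher number from compound 3 to compound 4 (0.26 log units; within the scatter) that may or may not clear the scatter. Compound 4 is therefore estimated at 12000 nM, within a range from 4000 nM to 35000 nM.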

Compound 4, solubility: 53700 nM
For compound 4 the middle estimate is 4.5-fold (0.65 log units) below the measured one; measured number outside the range, above it.
By their numbers in this assay, from the lowest: compounds 1 and 3 (each within the scatter of the next); then compounds 2 and 4 (each within the scatter of the next).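

In this assay, for the compounds shown here, putting (piperidin-1-yl)amino in place of tert-butyl on a carbonyl carbon gives an 8.1-fold higher number from compound 3 to compound 4 (0.91 log units; beyond the scatter), the first step in this set that can be read at a single place. It shows that this position can move the number well past the scatter while the rest of the molecule stays the same, something compounds 1, 2 and 3 could not show, as they differ from one another in more than one place. The change brings in a six-membered ring, a hydrogen-bond donor and a hydrogen-bond acceptor together, and no measurement shown here says why the number rises or which of these features matters.

Going by these compounds, a single step cannot separate those features, so it stays open whether a morpholine ring, a plain dimethylamino group or a short ethylamino chain on the same carbonyl carbon would give a step of similar size. On these data alone, it also stays open whether the same swap would have a similar effect on the cores of compound 1 and compound 2, whose carbonyl carbons carry other groups.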